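Aryl piperazine amides: dichlorophenyl to dimethylphenyl swap

The compounds below may be only part of what the source reports. "The series", "measured", "known", "first", "only" and "open" are said of these compounds alone.

Measured so far:
- compound 1 `Cc1nc(-c2ccccc2)c(C(=O)N2CCN(c3cccc(Cl)c3Cl)CC2)o1` gives 133 nM
- compound 2 `COc1cc(OC)cc(N2CCN(C(=O)c3onc(C)c3-c3cccc(F)c3)CC2)c1` gives 152 nM

Both numbers come from a functional assay on HL-60 cells (Homo sapiens) for inhibition, read by MTT assay, with a stated time of 72 h; on this read-out lower numbers stand for stronger inhibition and higher numbers for weaker inhibition. Compound 1 carries the lowest of the two numbers shown, but compound 2 lies within the usual scatter of it, so the two cannot be told apart on this read-out. Within the data shown here, compound 2 also differs from compound 1 in more than one place, so no single step between measured compounds is available in this assay.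

Compound 3 `Cc1cc(C)cc(N2CCN(C(=O)c3oc(C)nc3-c3ccccc3)CC2)c1` is the next candidate. It differs from compound 1 in one place only:

3,5-dimethylphenyl in place of 2,3-dichlorophenyl on an amine nitrogen in a ring

Among the measured compounds shown here, with no measured step of this kind, the expectation for this assay rests on compound 1 alone, whose value of 133 nM sets the starting point. A step from compound 1 to compound 3 of about a 1.5-fold higher number from compound 1 to compound 3 (0.18 log units; within the scatter) is expected, which would be small and not clearly beyond the scatter. Compound 3 is therefore estimated at 200 nM in this assay, with a range from 70 nM to 600 nM.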

Compound 3, half-maximal inhibitory concentration: 34.5 nM
Beside the measured number, compound 3's estimate is 5.8-fold (0.76 log units) above it, outside the stated range (below it).
By their numbers in this assay, from the lowest: compound 3; then compounds 1 and 2 (each within the scatter of the next).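

In this assay, the aryl group on the amine nitrogen of the six-membered non-aromatic ring with 2 nitrogen is a position where the read-out responds: 3,5-dimethylphenyl in place of 2,3-dichlorophenyl gives a 3.9-fold lower number from compound 1 to compound 3 (0.59 log units; beyond the scatter), a modest step on an otherwise unchanged core. The two groups have the same number of heavy atoms, each has one six-membered aromatic ring of carbon only, and neither has hydrogen-bond donors, hydrogen-bond acceptors or a net charge, so none of these counts tracks the step; the groups differ in carrying methyl rather than chlorine and in where those substituents sit. No measurement bears on why the number falls, so the step remains an observation on this one pair.

As far as these compounds go, this single step changes the substituent and its placement together, so the effect of either one alone stays open. An unsubstituted phenyl, a pyridine ring or a trifluoromethyl-bearing phenyl on the same nitrogen would show how far the value at this position can move, and whether the lower number depends on the methyl groups.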